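This account rests on a few compounds, and the source may have more. Where it says the series, first, only, none or still open, it means among the compounds named here.

For the measured compounds named here, in a functional assay on PC-3 cells (Homo sapiens) for cytotoxicity, read by MTT assay, with a stated time of 96 h (on this read-out lower numbers stand for stronger inhibition and higher numbers for weaker inhibition), compound 1 `CC[C@H](N)C(=O)N[C@@H]1C(=O)N2[C@@H](CC[C@@H]1CCN)CC[C@H]2C(=O)NC(c1ccccc1)c1ccccc1` gives 85200 nM, the only actual number so far. For its relative compound 2 `CC[C@H](NC)C(=O)N[C@@H]1C(=O)N2[C@@H](CC[C@@H]1CCN)CC[C@H]2C(=O)NC(c1ccccc1)c1ccccc1`, the assay reports only a limit, > 100000 nM. Compound 3 `CC[C@H](N)C(=O)N[C@@H]1C(=O)N2[C@@H](CC[C@@H]1CCNC(=O)c1ccccc1)CC[C@H]2C(=O)NC(c1ccccc1)c1ccccc1` keeps the core of compound 1 but has benzoyl in place of hydrogen on an amine nitrogen, turning 2-aminoethyl into 2-benzamidoethyl: benzoyl in place of hydrogen on an amine nitrogen. Going by the values given here, the sole measured step, an at least 1.1-fold higher number from compound 1 to compound 2 (0.06 log units; that floor lies within the scatter), is a different change, methyl in place of hydrogen on an amine nitrogen, so it offers only weak guidance for a benzoyl group. Because compound 1 gives 85200 nM there is little room towards weaker inhibition in this assay, so any clear change is expected to be towards stronger inhibition, with much uncertainty. The expected change is a 3.4-fold lower number from compound 1 to compound 3 (0.53 log units; beyond the scatter). For compound 3, the estimated value is 25000 nM, with an expected range of 4000 nM to 100000 nM.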

Compound 3, half-maximal inhibitory concentration: > 100000 nM
Compound 3 was reported as a limit; the forecaster's own chance of this, stated with the estimate: 25%; middle value at least 4.0-fold (0.60 log units) away from the limit.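

In this assay, benzoyl on this amine nitrogen, which turns 2-aminoethyl into 2-benzamidoethyl, brings no stronger inhibition: the step is an at least 1.1-fold higher number from compound 1 to compound 3 (0.06 log units; that floor lies within the scatter). As far as these compounds go, the entry for compound 3 is a limit and not a number, so the step gives only a floor, and whether compound 3 truly differs from compound 1 stays unknown. For the compounds shown here, this is the first reading for a change at the 2-aminoethyl end of the molecule, and it shows no move towards stronger inhibition, though it stops at the edge of what the assay reports: the limit of > 100000 nM in this assay, at which 2 of the 3 values shown sit.

The compounds shown leave open whether acetyl on this nitrogen, or a longer chain carrying the amine, would give a readable number. From the compounds shown here alone, it also stays open whether a methoxy group on the benzoyl ring would change the outcome.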